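Methyl in place of 2-(pyridin-2-yl)ethenyl: working notes

The compounds below may be only part of what the source reports. "The series", "measured", "known", "first", "only" and "open" are said of these compounds alone.

Compound 1 `COc1ccc(NC(=O)CCSc2ccc3c(/C=C/c4ccccn4)n[nH]c3c2)cc1C(F)(F)F` gives > 10000 nM (a limit, not a number)
Compound 2 `CN1CCN(Cc2ccc(NC(=O)CCSc3ccc4c(/C=C/c5ccccn5)n[nH]c4c3)cc2C(F)(F)F)CC1` gives 2480 nM

Among the compounds with values here, in an ADME assay on BaF3 cells (Mus musculus) for antiproliferative activity, read by CCK-8 assay, with a stated time of 72 h (a lower number here means a stronger inhibitor of growth, a higher number a weaker inhibitor of growth), compound 2 holds the only actual number so far, 2480 nM. Compound 1 sits at the limit of > 10000 nM in this assay, at which 1 of the 2 values shown sits. Within the data shown here, the one measured step, an at least 4.0-fold lower number from compound 1 to compound 2 (0.60 log units; beyond the scatter), came with (4-methylpiperazin-1-yl)methyl in place of methoxy on an aromatic carbon.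

Compound 3 `Cc1n[nH]c2cc(SCCC(=O)Nc3ccc(CN4CCN(C)CC4)c(C(F)(F)F)c3)ccc12` keeps that (4-methylpiperazin-1-yl)methyl group and differs from compound 2 at another place: methyl in place of 2-(pyridin-2-yl)ethenyl on an aromatic carbon. Among the measured compounds shown here, no measured step covers this place, so an at least 4.0-fold lower number from compound 1 to compound 2 (0.60 log units; beyond the scatter) shows only that a single change can move this assay beyond the scatter and gives no direct size for this one. The change removes a large group, and a weaker result is expected, though this rests on the structural change alone. The expected move is a 2.8-fold higher number from compound 2 to compound 3 (0.45 log units; beyond the scatter), and a reading reported only as a limit would be no surprise. For compound 3 the estimated value is 7000 nM, with an expected range from 2500 nM to 20000 nM.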

Compound 3, concentration for 50% growth inhibition: 3900 nM
The estimate for compound 3 lay 1.8-fold (0.25 log units) above the measured number; the range from low to high includes it.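

In this assay, methyl in place of 2-(pyridin-2-yl)ethenyl on an aromatic carbon of the five-membered aromatic ring gives a 1.6-fold higher number from compound 2 to compound 3 (0.20 log units; within the scatter), so this first reading at this place does not separate the two groups, despite the loss of 8 heavy atoms, a six-membered aromatic ring and a double bond. For this read-out, then, the 2-(pyridin-2-yl)ethenyl group is not needed to hold the level seen for compound 2, and a single methyl carbon serves equally well within the scatter. Nothing shown gives a cause for this flat step.

On these data alone, whether any group at this place can move the number beyond the scatter stays open, as only these two groups are compared here, and a hydrogen, an amine, a carboxylic acid or a longer alkyl chain would test it. Also open, as far as these compounds go, is whether the step at the other place, an at least 4.0-fold lower number from compound 1 to compound 2 (0.60 log units; beyond the scatter), carries over when methyl stands on the five-membered aromatic ring, since that step is known only with 2-(pyridin-2-yl)ethenyl present.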